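This account rests on a few compounds, and the source may have more. Where it says the series, first, only, none or still open, it means among the compounds named here.

Measured in a functional assay on A549 cells (Homo sapiens) for cytotoxicity, read by MTT assay, with a stated time of 24 h; a lower number here means a stronger inhibitor, a higher number a weaker inhibitor:

- Compound 1 `O=c1nc2ccc(Br)cn2cc1Cc1ccc(Br)cc1`: 102000 nM
- Compound 2 `O=c1nc2ccccn2cc1Cc1ccc(F)cc1`: > 1000000 nM (a limit of the assay, not a number)
- Compound 3 `O=c1nc2ccccn2cc1Cc1ccccc1`: 104000 nM

Compound 3, at 104000 nM, lies within the usual scatter of compound 1, at 102000 nM. For the measured compounds named here, these are the only two true numbers so far. The next compound, compound 4 `O=c1nc2ccccn2cc1Cc1ccc(Br)cc1`, keeps the core of compound 3 and carries bromo in place of hydrogen on an aromatic carbon, para to a large group (bromo in place of hydrogen on an aromatic carbon).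

Two measurements bear on this change. Going by the values given here, the first is a swap at the same carbon, an at least 9.6-fold lower number from compound 2 to compound 3 (0.98 log units; beyond the scatter). Going by these compounds, its true size stays open because of the limit of > 1000000 nM in this assay, at which 1 of the 3 values shown sits. It shows that a halogen at this carbon can matter, but fluoro is not bromo, so it sets no size for the new step. The second is compound 1, which already carries this bromo along with a second one on the core and still gives 102000 nM. Among the compounds with values here, that value argues against a large rise, although no measured step isolates the bromo alone.

The expected outcome is therefore little change, with some risk of a higher number. The step expected is a 1.3-fold higher number from compound 3 to compound 4 (0.10 log units; within the scatter). For compound 4 the estimated value is 130000 nM, with an expected range from 50000 nM to 500000 nM.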

Compound 4, half-maximal inhibitory concentration: > 1000000 nM
Compound 4: no number, only a limit; the forecaster's own chance of this, stated with the estimate: 15%; middle value at least 7.6-fold (0.88 log units) away from the limit.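

In this assay, bromo in place of hydrogen, para to a large group, gives an at least 9.6-fold higher number from compound 3 to compound 4 (0.98 log units; beyond the scatter), so a single bromine atom at this carbon moves the result beyond the scatter, and compound 2 with its fluoro fits the same picture. Compound 1 goes against any simple rule that a halogen here always has this result, since it carries the same bromo and still gives a true number: with hydrogen in place of its second bromo on the core, the result is an at least 9.8-fold higher number from compound 1 to compound 4 (0.99 log units; beyond the scatter), so what this carbon does depends on the rest of the molecule. Compound 4 gives only a limit of the assay, so the real size of both steps stays open, and the step from compound 2 to compound 4 cannot be read because the two compounds sit at the same limit: the limit of > 1000000 nM in this assay, at which 2 of the 4 values shown sit.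

The compounds shown leave open whether a methoxy group or an amine at this carbon would raise the number as the halogens do. They also leave open whether a bromo on the core would bring a fluoro compound back to a true number.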